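From a Fluorinated Ring to Cycloheptyl on the Shared Core

The source may hold more compounds than are shown below. What is called first, only, known or untested is meant among the compounds shown, and "the series" means these compounds.

Among the compounds with values here, compound 2 `O=C(O)c1ccccc1-c1ccc(CCc2ncc(Cc3cccc(F)c3F)[nH]2)cc1` gives 8 nM in an in vitro functional assay on cells for agonist activity at Bombesin receptor subtype-3 (Mus musculus), read by luminescence and calcium flux (on this read-out lower numbers stand for an effect already at smaller amounts and higher numbers for an effect only at larger amounts of compound), the lowest of the two numbers known here; compound 1 `N#Cc1cccc(Cc2cnc(CCc3ccc(-c4ccccc4C(=O)O)cc3)[nH]2)c1` gives 20 nM, and the step of a 2.5-fold lower number from compound 1 to compound 2 (0.40 log units; beyond the scatter) is modest. Compound 3 `O=C(O)c1ccccc1-c1ccc(CCc2ncc(CC3CCCCCC3)[nH]2)cc1` is not yet measured; it differs from compound 2 by cycloheptyl in place of 2,3-difluorophenyl on a saturated chain carbon bound to an aromatic carbon. Within the data shown here, the one measured step exchanged one aromatic ring for another and says little about replacing an aromatic ring with a non-aromatic one, so in this assay a modest step in either direction is expected, a loss somewhat more likely. Compound 3 is estimated at 25 nM, between 5 nM and 120 nM. The expected step is a 3.1-fold higher number from compound 2 to compound 3 (0.49 log units; beyond the scatter).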

Compound 3, half-maximal effective concentration: 5.7 nM
Compound 3: middle estimate off by 4.4-fold (0.64 log units), on the high side; the measured number falls inside the stated range.
By their numbers in this assay, from the lowest: compounds 3 and 2 (each within the scatter of the next); then compound 1.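

In this assay, a non-aromatic ring on a saturated chain carbon bound to an aromatic carbon holds up as well as the fluorinated aromatic ring, with cycloheptyl in place of 2,3-difluorophenyl giving a 1.4-fold lower number from compound 2 to compound 3 (0.15 log units; within the scatter). Set against 3-cyanophenyl, the same cycloheptyl gives a 3.5-fold lower number from compound 1 to compound 3 (0.55 log units; beyond the scatter), so among these three compounds an aromatic ring is not needed at this place. No evidence is available that would explain this result. Still open, on these data alone, is whether a smaller ring such as cyclopentyl, or an open chain such as hexyl, would do the same here. Also open, as far as these compounds go, is how an amine on the cycloheptyl ring would read.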